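Swapping a Fluorophenyl for a Furan on the Core

A few compounds are considered here, and "the series" means these few. Any claim that something is new, unique, unknown or untested is made for them only; others in the source may bear on it.

For the measured compounds named here, compound 1 `CCOC(=O)c1cnn(-c2nc(-c3ccccc3F)c(C#N)c(=O)n2C)c1N` is one of two compounds measured in a functional assay, with a stated time of 150 min; on this read-out lower numbers stand for stronger inhibition and higher numbers for weaker inhibition. In this assay compound 1 gives 87 ug/mL, the highest of the two numbers, while compound 2 `CN(C)c1ccc(-c2nc(NN)n(C)c(=O)c2C#N)cc1` gives 69 ug/mL; the two values lie within the scatter of each other. Compound 3 `CCOC(=O)c1cnn(-c2nc(-c3ccco3)c(C#N)c(=O)n2C)c1N` is not yet measured. It differs from compound 1 by furan-2-yl in place of 2-fluorophenyl on an aromatic carbon. Going by the values given here, no measured pair shows such a step, so no change beyond the scatter is expected in this assay. Compound 3 is therefore estimated at 80 ug/mL, ranging from 35 ug/mL to 180 ug/mL. The step of a 1.1-fold lower number from compound 1 to compound 3 (0.04 log units; within the scatter) is expected to stay within the scatter.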

Compound 3, half-maximal inhibitory concentration: 108 ug/mL
Estimate against measurement, compound 3: 1.4-fold (0.13 log units) below; the range from low to high includes it.
By their numbers in this assay, from the lowest: compounds 2, 1 and 3 (each within the scatter of the next).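

For the compounds shown here, compound 1 and compound 3 give the first one-place comparison at this aromatic carbon: in this assay, furan-2-yl in place of 2-fluorophenyl gives a 1.2-fold higher number from compound 1 to compound 3 (0.09 log units; within the scatter) for the change. On this core, then, a five-membered aromatic ring with one hetero atom stands in for a six-membered carbon ring without the read-out leaving the scatter. Nothing available explains this result. As far as these compounds go, whether an amine or a carboxylic acid on this carbon would move the number beyond the scatter remains open, as does whether the same swap behaves alike with a different group in place of the ethyl ester.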